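Cytotoxicity notes: methoxy to hydroxy on the shared core

The source may report more compounds than this note shows. Statements on the series, on what has been measured and on what is new or still open speak of the compounds shown alone.

Measured so far in a functional assay on A549 cells (Homo sapiens) for cytotoxicity, read by sulforhodamine B assay, with a stated time of 48 h, tested at 10 uM; a lower number here means a stronger effect, a higher number a weaker effect of the compound at the concentration tested:
- compound 1 `COc1cc(C)cc(-c2nn(CC#N)cc2-c2ccnc(-c3ccc(N(C)C)cc3)c2)c1`: -6%
- compound 2 `COc1cc(C)cc(-c2nn(CC#N)cc2-c2ccc(-c3cccc(C(C)=O)c3)nc2)c1`: -22%

Compound 1 stands highest of the two numbers; compound 2 lies lower, a gap beyond the scatter of this assay. For the measured compounds named here, no pair differing in one place has been measured, so no step size is known.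

Compound 3 `Cc1cc(O)cc(-c2nn(CC#N)cc2-c2ccnc(-c3ccc(N(C)C)cc3)c2)c1` is the next to be measured. It differs from compound 1 by hydrogen in place of methyl on an oxygen on an aromatic ring. Without a measured step of this kind, the change is expected to fall within the scatter, with no clear direction. The step of a number 4 percentage points lower from compound 1 to compound 3 (within the scatter) is therefore estimated as small. Compound 3 is expected to give about -10%, within a range from -28% to 8%.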

Compound 3, a percentage reported as activity, at one concentration (the size of the read-out at that concentration, not a potency): -8%
Beside the measured number, compound 3's estimate is 2 percentage points below it; low and high end bracket the measured number.
By their numbers in this assay, from the lowest: compound 2; then compounds 3 and 1 (each within the scatter of the next).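

In this assay, methoxy to hydroxy on the 3-methoxy-5-methylphenyl group gives the first step read at this position: a number 2 percentage points lower from compound 1 to compound 3 (within the scatter). On the core of compound 1, the methyl on the oxygen can therefore be exchanged for hydrogen without a shift beyond the scatter, at the single concentration tested; the read-out is not a potency. Nothing at hand bears on the origin of this result.

The compounds shown leave open whether the same change on the core of compound 2 gives a step of similar size. They also leave open how a longer chain on the oxygen, such as ethyl, or an amine in place of the hydroxy would read in this assay.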